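A few compounds are considered here, and "the series" means these few. Any claim that something is new, unique, unknown or untested is made for them only; others in the source may bear on it.

Compound 1 `C[C@H]1N=C2C[C@H]3C[C@H](C3(C)C)[C@@]2(C)OC1=O` gives only a limit in an ADME assay on MCF-10A cells (Homo sapiens) for antiproliferative activity, read by sulforhodamine B assay, with a stated time of 48 h (a lower number here means a stronger inhibitor, a higher number a weaker inhibitor), > 1800000 nM.
Compound 2 `CC(C)(C)OC(=O)NCCCC[C@H]1N=C2C[C@H]3C[C@H](C3(C)C)[C@@]2(C)OC1=O` also gives only a limit, > 1300000 nM.
Compound 3 `CC(C)(C)OC(=O)NCCCC[C@@H]1N=C2C[C@@H]3C[C@@H](C3(C)C)[C@]2(C)OC1=O` gives a limit as well, > 800000 nM.

Compound 1 therefore cannot be placed on the numbers: its value is a limit of this assay, as are the other two values shown. Compound 4 `C[C@@H]1N=C2C[C@@H]3C[C@@H](C3(C)C)[C@]2(C)OC1=O` differs from compound 1 only in configuration: the two compounds have the same atoms and bonds and differ only in configuration as drawn: 4 of 4 stereo elements differ (all stereocentres are inverted: mirror images); a stereocentre at a saturated ring carbon is drawn R in compound 1 and S in compound 4; a stereocentre at a saturated ring carbon is drawn R in compound 1 and S in compound 4; a stereocentre at a saturated ring carbon is drawn R in compound 1 and S in compound 4; a stereocentre at a saturated ring carbon is drawn R in compound 1 and S in compound 4. Going by the values given here, the one measured step of the same kind is a step that the two limits leave unreadable from compound 2 to compound 3, where compounds 2 and 3 differ only in configuration the fact that compounds 2 and 3 differ only in the configuration as drawn and both sit at limits the limit of > 1300000 nM in this assay, at which 1 of the 3 values shown sits (the limit of > 800000 nM in this assay, at which 1 of the 3 values shown sits). No readable change is expected, so compound 4 is estimated at 1800000 nM, within 500000 nM to 6000000 nM, the expected step being a number no higher from compound 1 to compound 4 (the limit leaves the size open), most likely reported again as a limit.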

Compound 4, half-maximal inhibitory concentration: > 2000000 nM
Compound 4: a limit, no number; the forecaster's own chance of this, stated with the estimate: 90%; middle value at least 1.1-fold (0.04 log units) from the limit.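

Going by these compounds alone, compound 1 and compound 4 are mirror images, and both give only limits in this assay, so no step between them can be read. With every compound shown at a limit, whether configuration changes activity here at all stays open.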